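Carboxyphenoxy Arm Replaces Methoxyphenyl on a Shared Core

This account rests on a few compounds, and the source may have more. Where it says the series, first, only, none or still open, it means among the compounds named here.

Measured compounds:
Compound 1, `COc1ccccc1-n1nc(C)c2c1NC(=O)[C@H](C)S[C@@H]2c1ccc(Oc2ccccc2)cc1`: 3300 nM
Compound 2, `COc1cccc(-c2ccc([C@H]3S[C@@H](C)C(=O)Nc4c3c(C)nn4-c3ccccc3C)cc2)c1`: 1800 nM
Compound 3, `Cc1nn(-c2ccccc2F)c2c1C(c1ccc(Oc3ccccc3)cc1)SC(C)C(=O)N2`: 3900 nM

All three were tested in an assay on isolated protein for agonist activity at Bile acid receptor (Homo sapiens), read by AlphaScreen, with a stated time of 30 min; on this read-out lower numbers stand for an effect already at smaller amounts and higher numbers for an effect only at larger amounts of compound. Compound 2 gives the lowest of the three numbers. Its gap to compound 1 is within the usual scatter of repeated measurements, so these two cannot be ranked against each other; its gap to compound 3 is beyond the scatter. Compound 4, `Cc1ccccc1-n1nc(C)c2c1NC(=O)[C@H](C)S[C@@H]2c1ccc(Oc2cccc(C(=O)O)c2)cc1`, has not yet been measured. It differs from compound 2 in a single place: 3-carboxyphenoxy in place of 3-methoxyphenyl on an aromatic carbon. Going by the values given here, no pair of measured compounds isolates this change, so there is no measured step to lean on. The three measured numbers lie close together, and a step of moderate size in either direction would still fit that picture. The expected step of a 1.2-fold lower number from compound 2 to compound 4 (0.08 log units; within the scatter) is small, toward an effect at smaller amounts, and not clearly beyond the scatter. Compound 4 is expected to give about 1500 nM in this assay. For compound 4 the estimated range runs from 400 nM to 6000 nM.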

Compound 4, half-maximal effective concentration: "not active" (no number reported)
For compound 4 the study gives words and no number, and the estimate cannot be compared.
By their numbers in this assay, from the lowest: compounds 2, 1 and 3 (each within the scatter of the next, the first and the last beyond it).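

In this assay, going by these compounds alone, compound 4 is reported only as not active, without a number, so no step from compound 2 to compound 4 can be read. No measurement shown here offers an explanation for this result. From the compounds shown here alone, what the 3-carboxyphenoxy group alone does on this core remains open.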